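This account rests on a few compounds, and the source may have more. Where it says the series, first, only, none or still open, it means among the compounds named here.

In a functional assay on PC-9 cells (Homo sapiens) for inhibition, read by MTT assay, with a stated time of 48 h, tested at 10 uM (a higher number here means more inhibition at the concentration tested (going by the name of the read-out), a lower number less inhibition), three compounds have been measured. Compound 1 `COc1cc(NC(=O)Nc2cc(Nc3ccc(OC)c(C)c3)ncn2)cc(OC)c1` gives 62%, compound 2 `CCc1ccc(Nc2cc(NC(=O)Nc3c(Cl)cccc3Cl)ncn2)cc1` gives 70.1%, and compound 3 `COc1cc(Nc2cc(NC(=O)Nc3c(Cl)cccc3Cl)ncn2)cc(OC)c1` gives 90%. Compound 1 thus has the lowest of the three numbers: the value of compound 2 lies closest to it, within the usual scatter of this kind of measurement, while compound 3 stands apart from it by a gap beyond the scatter. Compound 4 `COc1cc(NC(=O)Nc2cc(Nc3ccc(C)c(C)c3)ncn2)cc(OC)c1` has not yet been measured. It differs from compound 1 in one place: methyl in place of methoxy on an aromatic carbon. Among the measured compounds shown here, no pair of measured compounds separated by a single change is available, so the size of a step in this assay for such a change is not known from these data. Because compound 1 gives 62% and the change is a small one, the step of a number 2 percentage points lower from compound 1 to compound 4 (within the scatter) is expected to be small and to stay within the scatter in either direction. Compound 4 is therefore estimated to give 60%, in the range 42% to 78%.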

Compound 4, a percentage reported as inhibition, at one concentration (the size of the read-out at that concentration, not a potency): 66%
Beside the measured number, compound 4's estimate is 6 percentage points below it, and the stated range covers the measured number.
By their numbers in this assay, from the lowest: compounds 1, 4 and 2 (each within the scatter of the next); then compound 3.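

Among the compounds shown here, the step of a number 4 percentage points higher from compound 1 to compound 4 (within the scatter) is the first single change that can be read in this assay. At this place, on an aromatic carbon para to a large group, it shows that the 4-methoxy-3-methylphenyl and 3,4-dimethylphenyl groups cannot be told apart by this read-out, so the oxygen of the methoxy is not needed to hold the number here. Nothing on hand gives a reason for this result.

As far as these compounds go, it remains open whether another group at this place, such as an amine, a hydroxyl or a longer chain like ethoxy, would give a step beyond the scatter. From the compounds shown here alone, it is also open whether methyl and methoxy would stay equally close at this place in compounds that carry the chlorine-bearing aromatic ring of compound 2.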